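Removing a Methyl from Sulfur in Quinazoline-like Cytotoxic Agents

This account rests on a few compounds, and the source may have more. Where it says the series, first, only, none or still open, it means among the compounds named here.

Three compounds sharing one core were tested in a functional assay on CCRF-CEM cells (Homo sapiens) for cytotoxicity, read by MTT assay, with a stated time of 72 h; on this read-out higher numbers stand for weaker inhibition of growth and lower numbers for stronger inhibition of growth. Compound 1 `Sc1nc(NCc2ccccc2)c2ccccc2n1` gives 82400 nM in this assay. Compound 2 `CSc1nc(NCc2ccccc2)c2ccccc2n1` gives 87900 nM, and compound 3 `COc1ccc(CNc2nc(SC)nc3ccccc23)cc1` gives 93700 nM. The three numbers sit close together: a 1.1-fold lower number from compound 2 to compound 1 (0.03 log units; within the scatter) and a 1.1-fold higher number from compound 2 to compound 3 (0.03 log units; within the scatter), so neither change moves the read-out by more than the usual scatter.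

Compound 4 `COc1ccc(CNc2nc(S)nc3ccccc23)cc1` has not yet been measured. It differs from compound 3 by hydrogen in place of methyl on a sulfur. The same change separates compound 2 from compound 1, namely (hydrogen in place of methyl on a sulfur), and the place lines of the two changes match word for word, so it is the same change made on a different partner. The two cores differ by methoxy in place of hydrogen on an aromatic carbon.

Since the step from compound 2 to compound 1 stayed within the scatter, a similarly small step is expected from compound 3 to compound 4, of about a 1.0-fold lower number from compound 3 to compound 4 (0.02 log units; within the scatter) in this assay. Compound 4 is therefore estimated at 90000 nM, most likely between 45000 nM and 180000 nM.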

Compound 4, concentration for 50% growth inhibition: 10400 nM
For compound 4 the middle estimate is 8.7-fold (0.94 log units) above the measured one; the measured number lies below the stated range.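

In this assay, hydrogen in place of methyl on a sulfur gives a 9.0-fold lower number from compound 3 to compound 4 (0.95 log units; beyond the scatter) on the core that carries methoxy, but the same change on the core without methoxy gives a very different result: the same change on two cores in this assay, a 1.1-fold lower number (0.03 log units; within the scatter) from compound 2 to compound 1 and a 9.0-fold lower number (0.95 log units; beyond the scatter) from compound 3 to compound 4, 8.4-fold (0.93 log units) apart, beyond the scatter of two such steps.
Read the other way round, methoxy in place of hydrogen on an aromatic carbon gives a 7.9-fold lower number from compound 1 to compound 4 (0.90 log units; beyond the scatter) when the sulfur carries hydrogen, and this too departs from what the same change does when the sulfur carries methyl: the same change on two cores in this assay, a 1.1-fold higher number (0.03 log units; within the scatter) from compound 2 to compound 3 and a 7.9-fold lower number (0.90 log units; beyond the scatter) from compound 1 to compound 4, 8.4-fold (0.93 log units) apart, beyond the scatter of two such steps.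
So the effect of either change depends on the other, and a step measured on one core could not be carried over to the other here, although this rests on compound 4 alone and does not show why the two changes work together or whether the same holds on any other core.

The compounds shown leave open whether another group in place of methoxy, such as a chlorine or an amine, would pair with the sulfanyl in the same way. They also leave open how a longer chain on the sulfur would compare with methyl.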